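Alkoxy for acetyl on the aryl of the styryl imine series

A few compounds are considered here, and "the series" means these few. Any claim that something is new, unique, unknown or untested is made for them only; others in the source may bear on it.

Two members of this series have numbers in an assay on membranes from brain for displacement of a labelled ligand from Neuronal acetylcholine receptor; alpha4/beta2 (Rattus norvegicus), with a stated time of 3 h; on this read-out higher numbers stand for weaker inhibition and lower numbers for stronger inhibition. Compound 1 `CC(=O)c1ccc(/C=C2\CCCN=C2c2cccnc2)cc1` gives 4490 nM in this assay, the higher of the two numbers shown. Compound 2 `COc1ccc(/C=C2\CCCN=C2c2cccnc2)c(OC(C)=O)c1` gives 770 nM in this assay, and the gap between the two values lies beyond the scatter. Compound 3 `CC(C)(C)Oc1ccc(/C=C2\CCCN=C2c2cccnc2)cc1` has not been measured. It differs from compound 1 in one place: tert-butoxy in place of acetyl on an aromatic carbon, the new group sitting on an aromatic carbon of a six-membered aromatic ring of carbon only, para to a large group. Among the compounds with values here, no step between measured compounds bears on this exchange, so the direction rests only on what compound 1 and compound 2 show. For compound 3 a modest step toward a lower number is expected, a 2.0-fold lower number from compound 1 to compound 3 (0.31 log units; beyond the scatter), within or a little beyond the scatter. Compound 3 is therefore estimated at 2200 nM in this assay, with a range from 500 nM to 9000 nM.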

Compound 3, inhibition constant: 2170 nM
For compound 3 the middle estimate is 1.0-fold (0.01 log units) above the measured one, within the range that was stated.
By their numbers in this assay, from the lowest: compound 2; then compound 3; then compound 1.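

In this assay, within the data shown here, tert-butoxy in place of acetyl on the aromatic carbon para to a large group gives a 2.1-fold lower number from compound 1 to compound 3 (0.32 log units; beyond the scatter), the first step that can be read at a single place. This position therefore tolerates the larger tert-butoxy without any loss of binding, and the exchange also removes the double bond of the acetyl while leaving the counts of hydrogen-bond donors and acceptors unchanged. No measurement at hand explains the size or direction of this step.

The compounds shown leave open whether the step follows the oxygen attached to the ring or the branched tert-butyl part. An ethoxy group, an amine or a carboxylic acid at this same position would test how far the trend extends.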